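The source may report more compounds than this note shows. Statements on the series, on what has been measured and on what is new or still open speak of the compounds shown alone.

Working notes on the diaryl ether thiourea series, measured in a functional assay on PC-3 cells (Homo sapiens) for cytotoxicity, read by MTT assay, with a stated time of 48 h; a higher number here means a weaker inhibitor, a lower number a stronger inhibitor.

Of the compounds shown here, two carry numbers so far. Compound 1 `O=C(NCc1ccccc1)c1cc(Oc2cccc(NC(=S)Nc3cccc(C(F)(F)F)c3)c2)ccn1` gives 11000 nM in this assay. Compound 2 `CNC(=O)c1cc(Oc2cccc(NC(=S)Nc3ccc(OC(F)(F)F)cc3)c2)ccn1` gives 34700 nM, the higher of the two numbers; the gap to compound 1 lies beyond the usual scatter of repeated measurements, so compound 2 stands as the weaker of the pair on what is known.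

Compound 3 `O=C(NCc1ccccc1)c1cc(Oc2cccc(NC(=S)Nc3ccc(OC(F)(F)F)cc3)c2)ccn1` has not yet been measured. It differs from compound 2 in one place: phenyl in place of hydrogen on a saturated chain carbon bound to an amide-type nitrogen. Among the measured compounds shown here, no measured pair shows this change on its own; compound 1 already carries the benzylcarbamoyl group but also differs from compound 3 elsewhere on the thiourea aryl ring, so its value can only serve as a rough pointer. On that basis a step toward a lower number, beyond the scatter, is expected, a 2.3-fold lower number from compound 2 to compound 3 (0.36 log units; beyond the scatter). The estimate for compound 3 in this assay is 15000 nM, with a range from 6000 nM to 40000 nM.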

Compound 3, half-maximal inhibitory concentration: 6800 nM
Compound 3: the middle estimate sits 2.2-fold (0.34 log units) above what was measured; low and high end bracket the measured number.
By their numbers in this assay, from the lowest: compounds 3 and 1 (each within the scatter of the next); then compound 2.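

In this assay the change from methylcarbamoyl to benzylcarbamoyl, phenyl in place of hydrogen on a saturated chain carbon bound to an amide-type nitrogen, now reads on its own as a modest gain (a 5.1-fold lower number from compound 2 to compound 3 (0.71 log units; beyond the scatter)). With benzylcarbamoyl held fixed, 4-(trifluoromethoxy)phenyl in place of 3-(trifluoromethyl)phenyl on an amide-type nitrogen does not separate the pair (a 1.6-fold lower number from compound 1 to compound 3 (0.21 log units; within the scatter)), so among these steps only the one at the chain carbon lies beyond the scatter. Nothing at hand gives a reason for that step.

Going by these compounds, whether the aromatic ring matters, or chain length alone, stays open: a straight butyl chain in place of benzyl would test that. Also open, on these data alone, is whether a carboxylic acid or an amine on the benzyl ring keeps the gain.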